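Allyl for sec-Butyl on the Amide Nitrogen

This account rests on a few compounds, and the source may have more. Where it says the series, first, only, none or still open, it means among the compounds named here.

Compound 1, `Cc1ccc(OCC(=O)N(Cc2cccs2)c2ccccn2)cc1`, gives 200 nM in an assay on HEK293 cells for agonist activity at transient receptor potential cation channel subfamily M member 8 (Homo sapiens), read by fluorescence and calcium flux, with a stated time of 15 min; on this read-out higher numbers stand for an effect only at larger amounts of compound and lower numbers for an effect already at smaller amounts.
Compound 2, `CCC(C)N(Cc1cccs1)C(=O)COc1ccc(C)cc1`, gives 2000 nM in this assay.
Compound 3, `CCN(Cc1cccs1)C(=O)COc1ccc2c(c1)CCCC2`, gives 689 nM in this assay.

Among the three measured compounds, compound 2 stands at the highest number, beyond the scatter from both others; compound 3 is nearest and compound 1 furthest. Compound 4, `C=CCN(Cc1cccs1)C(=O)COc1ccc(C)cc1`, has not yet been measured. It differs from compound 2 in a single place: allyl in place of sec-butyl on an amide-type nitrogen.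

For the measured compounds named here, only one measured step touches the same nitrogen, a 10-fold higher number from compound 1 to compound 2 (1.00 log units; beyond the scatter), where an aryl substituent was exchanged for sec-butyl. Going by the values given here, no measured pair exchanges one alkyl chain for another at that position. Compound 3 carries ethyl there but also a different aryl ether, so its value can only be set beside that of compound 2 without a computed step; the two values show a lower number for compound 3.

Taken together, the step of a 10-fold higher number from compound 1 to compound 2 (1.00 log units; beyond the scatter) and the lower value of compound 3 suggest that a smaller group on this nitrogen may move the number downward. For compound 4 the expected step is therefore a 2.0-fold lower number from compound 2 to compound 4 (0.30 log units; within the scatter) in this assay, a modest move toward lower numbers, though one not far beyond the scatter. The estimate for compound 4 is 1000 nM, within a range from 300 nM to 3000 nM.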

Compound 4, half-maximal effective concentration: 20 nM
Estimate against measurement, compound 4: 50-fold (1.70 log units) above; measured number outside the range, below it.
By their numbers in this assay, from the lowest: compound 4; then compound 1; then compound 3; then compound 2.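

In this assay, for the compounds shown here, the change from sec-butyl to allyl on the amide-type nitrogen gives a 100-fold lower number from compound 2 to compound 4 (2.00 log units; beyond the scatter) and is the largest step, which shows that this position responds strongly to an exchange between two non-ring groups, something the earlier compounds, with only an exchange of pyridin-2-yl for sec-butyl at this nitrogen, did not show. The pyridin-2-yl group of compound 1 is also not required for a low number here, as allyl in its place gives a 10-fold lower number from compound 1 to compound 4 (1.00 log units; beyond the scatter). This reverses the direction that sec-butyl in the same place had suggested for a non-ring group. No measured information is available to explain why allyl and sec-butyl differ so widely on this nitrogen.

The compounds shown leave open whether the step belongs to the double bond of allyl or to its smaller count of carbon atoms, and a propyl group on the same nitrogen would separate the two. From the compounds shown here alone, it also remains open how far the low number persists with a longer chain carrying a double bond, such as a butenyl group, or with a triple bond, as in a propargyl group.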